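Benzyl for 2-chlorophenyl on a weak aminopyrazolopyrimidine

A few compounds are considered here, and "the series" means these few. Any claim that something is new, unique, unknown or untested is made for them only; others in the source may bear on it.

Compound 1 `N[C@@H]1CCCN(c2cc(Nc3ccccc3Cl)n3nccc3n2)C1` is tested in an assay on isolated protein for inhibition of Dipeptidyl peptidase 9 (Homo sapiens); a higher number here means a weaker inhibitor, a lower number a stronger inhibitor. In this assay compound 1 gives only a limit, > 100000 nM, not a number. Two related compounds share its core. Compound 2 `Fc1ccc(Nc2cc(N3CCNCC3)nc3ccnn23)c(F)c1` also returns only a limit in this assay, > 100000 nM. Compound 3 `Cc1ccc(Nc2cc(N3CCNCC3)nc3ccnn23)c(C)c1` likewise gives only a limit, > 100000 nM. Going by the values given here, the one step that can be compared, a step that the two limits leave unreadable from compound 2 to compound 3, is therefore unreadable in size, because the limit of > 100000 nM in this assay, at which 3 of the 3 values shown sit, is where all three values sit.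

Compound 4 `N[C@@H]1CCCN(c2cc(NCc3ccccc3)n3nccc3n2)C1` differs from compound 1 in one place: benzyl in place of 2-chlorophenyl on a nitrogen on an aromatic ring. Among the compounds with values here, no measured step changes a group on this nitrogen into benzyl, so nothing among the three compounds speaks for or against a gain in potency from this exchange. Since every compound made so far is too weak to be measured, the expectation for compound 4 is that it will most likely also sit at the limit, and the step that the limit leaves unreadable from compound 1 to compound 4 is estimated to be no change beyond the scatter. Compound 4 is expected to give about 150000 nM, within a range from 30000 nM to 600000 nM.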

Compound 4, half-maximal inhibitory concentration: > 100000 nM
Compound 4 ended at the assay's limit; the forecaster's own chance of this, stated with the estimate: 85%; the middle value is on the limit's open side.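

Compound 1 and compound 4 both return only a limit, so the exchange of 2-chlorophenyl for benzyl cannot be read as a step of any size: the limit of > 100000 nM in this assay, at which 4 of the 4 values shown sit. The compounds shown leave open whether either group gives real inhibition in this assay and what change to the shared core would bring a measurable value.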